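The source may hold more compounds than are shown below. What is called first, only, known or untested is meant among the compounds shown, and "the series" means these compounds.

Measured so far:
- Compound 1, `N[C@@H](COP(=O)(O)OCCCOC(=O)CCc1ccccc1OCc1cccc(Cc2ccccc2)c1)C(=O)O`: 0.077
- Compound 2, `N[C@@H](COP(=O)(O)OCCCOC(=O)CCc1ccccc1OCc1cccc(Oc2cccc(Cl)c2)c1)C(=O)O`: 0.53
- Compound 3, `N[C@@H](COP(=O)(O)OCCCOC(=O)CCc1ccccc1OCc1cccc(Oc2ccc(I)cc2)c1)C(=O)O`: 0.82

In an assay on cells for activation of probable G-protein coupled receptor 34 (Mus musculus), with a stated time of 1 h (a lower number here means a smaller maximal response, a higher number a larger maximal response), compound 3 stands highest of the three, with compound 2 nearest at a number 0.29 higher from compound 2 to compound 3 (beyond the scatter) and compound 1 furthest at a number 0.74 higher from compound 1 to compound 3 (beyond the scatter). Compound 4, `CC(C)(C)c1ccc(Oc2cccc(COc3ccccc3CCC(=O)OCCCOP(=O)(O)OC[C@H](N)C(=O)O)c2)cc1`, keeps the core of compound 3 and differs in one place: tert-butyl in place of iodo on an aromatic carbon. For the measured compounds named here, no measured step swaps a halogen for an alkyl group on that ring; the only step on the outer ring, a number 0.29 higher from compound 2 to compound 3 (beyond the scatter), moved both the group and its place at once, so it bears only loosely. A small step in this assay, within or near the scatter, is therefore expected, shown as a number 0.070 lower from compound 3 to compound 4 (within the scatter). Compound 4 is estimated at 0.75, in the range 0.5 to 1.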

Compound 4, intrinsic activity: the largest response reached, as a fraction of the reference agonist's: 0.079
Compound 4: middle estimate off by 0.67, on the high side, and the stated range ends above it.
By their numbers in this assay, from the lowest: compounds 1 and 4 (each within the scatter of the next); then compound 2; then compound 3.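

In this assay, for the compounds shown here, this single carbon on the outer ring matters far more than the earlier compounds could show: tert-butyl in place of iodo gives a large fall (a number 0.74 lower from compound 3 to compound 4 (beyond the scatter)), and the 4-(tert-butyl)phenyl group also falls short of 3-chlorophenyl (a number 0.45 lower from compound 2 to compound 4 (beyond the scatter)). The phenoxy link alone therefore does not secure a high response, since 4-(tert-butyl)phenoxy cannot be told apart from benzyl (a number 0.0020 higher from compound 1 to compound 4 (within the scatter)). No measurement shown here accounts for this loss.

The compounds shown leave open how a methyl, a bromine or a methoxy group on that same carbon would behave.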